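Swapping a methylphenyl for a chlorophenyl on the piperazine

The source may hold more compounds than are shown below. What is called first, only, known or untested is meant among the compounds shown, and "the series" means these compounds.

Measured compounds:
- compound 1, `CCCc1nc(-c2ccccc2)c(CNCCN2CCN(c3ccccc3Cl)CC2)o1`, 4370 nM
- compound 2, `CCCc1nc(-c2ccccc2)c(CNCCCN2CCN(c3cccc(C)c3)CC2)o1`, 1190 nM
- compound 3, `CCCc1nc(-c2ccccc2)c(CNCCN2CCN(c3ccc(Cl)cc3)CC2)o1`, 2820 nM

All three share one core and differ only in the linker and in the aryl group on the amine nitrogen in a ring. In an assay on HEK293 cells for inhibition of Voltage-dependent T-type calcium channel subunit alpha-1G (Homo sapiens), read by patch clamp (on this read-out higher numbers stand for weaker inhibition and lower numbers for stronger inhibition), compound 2 gives the lowest number of the three; the steps from it to compound 3 and to compound 1 both lie beyond the scatter, so compound 2 is the strongest inhibitor measured here.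

Compound 4, `CCCc1nc(-c2ccccc2)c(CNCCCN2CCN(c3ccccc3Cl)CC2)o1`, has not been measured. It differs from compound 2 by 2-chlorophenyl in place of 3-methylphenyl on an amine nitrogen in a ring.

Going by the values given here, only one measured step touches a chlorophenyl: a 1.5-fold lower number from compound 1 to compound 3 (0.19 log units; within the scatter), which shows that moving the chlorine around the ring changes little. Among the compounds with values here, no measured pair compares a methylphenyl with a chlorophenyl on the same linker, and compound 1 and compound 3 also carry a shorter linker than compound 2, so the effect of the aryl swap alone cannot be separated. Since compound 1 carries the same 2-chlorophenyl and gives 4370 nM, a modestly higher number than compound 2 is expected for compound 4 in this assay, as a 1.8-fold higher number from compound 2 to compound 4 (0.27 log units; within the scatter). The estimate for compound 4 is therefore 2200 nM, with a range from 900 nM to 5500 nM.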

Compound 4, half-maximal inhibitory concentration: 2800 nM
Compound 4: the middle estimate sits 1.3-fold (0.10 log units) below what was measured, within the range that was stated.
By their numbers in this assay, from the lowest: compound 2; then compounds 4, 3 and 1 (each within the scatter of the next).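

In this assay, going by these compounds alone, compounds on the same linker can now be compared for the first time, and the change of aryl group on the piperazine nitrogen gives a 2.4-fold higher number from compound 2 to compound 4 (0.37 log units; beyond the scatter), so this group affects the read-out even when the linker stays fixed. The new result also gives a pair that differs only in the linker and carries the same 2-chlorophenyl: compound 4 gives 2800 nM and compound 1 gives 4370 nM. No measurement here explains why the aryl swap shifts the number.

The swap changes both the substituent and its place on the phenyl ring, so the two contributions cannot be told apart. A 2-methylphenyl or a 3-chlorophenyl on the same linker would separate them.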